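A few compounds are considered here, and "the series" means these few. Any claim that something is new, unique, unknown or untested is made for them only; others in the source may bear on it.

Measured so far:
- compound 1, `Nc1scc(-c2ccc(Cl)cc2)c1C(=O)c1ccccc1`: 46%
- compound 2, `Nc1scc(-c2ccc(F)cc2)c1C(=O)c1ccc(Cl)cc1`: 62%

Of the compounds shown here, two have been read in a functional assay on CHO cells for agonist activity at adenosine receptor A1 (Homo sapiens), read by fluorescence and ERK phosphorylation, with stated times of 30 min and 1.5 h, tested at 3 uM; a lower number here means a weaker effect, a higher number a stronger effect of the compound at the concentration tested. Compound 1 gives 46% in this assay. Compound 2 gives 62% in this assay, which is the highest of the two numbers; compound 1 lies a number of percentage points lower, and that gap is beyond the usual scatter. Within the data shown here, no pair of measured compounds differs in a single place, so no isolated step is available to lean on.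

The next compound, compound 3, `Nc1scc(-c2ccc(Cl)cc2)c1C(=O)c1ccc(Cl)cc1`, is not yet measured in this assay. Compared with compound 2 the change is chloro in place of fluoro on an aromatic carbon of a six-membered aromatic ring of carbon only, para to a large group.

Among the measured compounds shown here, with only two numbers and no single-place step, the expected step from compound 2 to compound 3 is small: compound 3 is estimated to move by no change at the digits printed from compound 2 to compound 3 (within the scatter), not clearly beyond the scatter in either direction. Compound 3 is accordingly expected to give about 62% in this assay, with a range from 42% to 80%.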

Compound 3, a percentage reported as activity, at one concentration (the size of the read-out at that concentration, not a potency): 50%
The estimate for compound 3 lay 12 percentage points above the measured number; the measured number falls inside the stated range.
By their numbers in this assay, from the lowest: compounds 1 and 3 (each within the scatter of the next); then compound 2.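

In this assay, among these compounds, chloro in place of fluoro on an aromatic carbon, para to a large group, gives a number 12 percentage points lower from compound 2 to compound 3 (beyond the scatter) and supplies the first single-place reading at this position, which shows that the read-out here is not indifferent to the choice between these two halogens. Chloro in place of hydrogen on an aromatic carbon at a different place in the structure gives a number 4 percentage points higher from compound 1 to compound 3 (within the scatter) and so leaves no readable change in this assay on the background carrying the 4-chlorophenyl group, which means the two single-place changes do not read alike in these compounds. No measurement shown here bears on the reason for either step.

As far as these compounds go, it remains open whether 4-fluorophenyl to 4-chlorophenyl gives a similar step when hydrogen replaces the chloro at the second substituted place, and how a methoxy group, an amine or a carboxylic acid would read para to a large group. From the compounds shown here alone, these numbers also give the size of the effect at one concentration, so the relative potency of the three compounds remains open.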